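A few compounds are considered here, and "the series" means these few. Any claim that something is new, unique, unknown or untested is made for them only; others in the source may bear on it.

Measured in a functional assay on THP-1 cells (Homo sapiens) for cytotoxicity, read by MTT assay, with a stated time of 24 h; a higher number here means a weaker inhibitor, a lower number a stronger inhibitor:
Compound 1 `C=C1CC[C@H]2C(C)(C)CCC[C@]2(C)[C@H]1CCC(C)CC(=O)O`: > 200000 nM, a limit of the assay
Compound 2 `COc1ccc(/C=C2\CC[C@H]3C(C)(C)CCC[C@]3(C)[C@H]2CCC(C)CC(=O)O)cc1`: > 200000 nM, a limit of the assay
Compound 3 `COc1ccc(/C=C2\CC[C@H]3C(C)(C)CCC[C@]3(C)[C@H]2CCC(C)CC(=O)O)cc1OC`: 178000 nM, a measured number

Compound 2 stands at the limit of > 200000 nM in this assay, at which 2 of the 3 values shown sit. That is a limit and not a measured number, so the starting point for what follows is only loosely fixed.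

Compound 4 `CC(CC[C@H]1/C(=C/c2ccc(F)cc2)CC[C@H]2C(C)(C)CCC[C@]12C)CC(=O)O` differs from compound 2 in one place, with fluoro in place of methoxy on an aromatic carbon, para to a large group (fluoro in place of methoxy on an aromatic carbon). In other words, 4-methoxyphenyl becomes 4-fluorophenyl.

Among the measured compounds shown here, only one measured step touches this aromatic ring, and it adds a methoxy in place of hydrogen: an at least 1.1-fold lower number from compound 2 to compound 3 (0.05 log units; that floor lies within the scatter). On these data alone, that floor lies within the scatter, and the true size of the step stays unknown since it starts from a limit. It bears on the new change only indirectly, as it removes no methoxy and brings in no fluoro. For the measured compounds named here, no measured compound here carries fluoro.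

With so little to go on, no shift beyond the scatter is expected in either direction, and the estimated step is a number no higher from compound 2 to compound 4 (the limit leaves the size open). In this assay the estimate for compound 4 is 200000 nM, with an expected range from 120000 nM to 320000 nM, and the assay may well report only a limit again.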

Compound 4, half-maximal inhibitory concentration: > 200000 nM
Compound 4 gave a limit, no number; the forecaster's own chance of this, stated with the estimate: 60%; the middle value lies on the limit itself.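

In this assay compound 4 gives > 200000 nM, which is a limit of the assay, so this ring now carries fluoro as well as methoxy without a measured number appearing for either group alone. Among the compounds shown here, the only readable comparison for the new compound, against the 3,4-dimethoxyphenyl ring of compound 3, is an at least 1.1-fold higher number from compound 3 to compound 4 (0.05 log units; that floor lies within the scatter), so it shows no real difference between these two rings. The step from compound 2 to compound 4 joins two limits and cannot be read, which leaves the swap of methoxy for fluoro without a size, and most of the series now gives no number to compare: the limit of > 200000 nM in this assay, at which 3 of the 4 values shown sit.

On these data alone, whether any group on this aromatic ring can move the result beyond the scatter remains open, and so does the true size of the effect of fluoro compared with methoxy. An amine or a hydroxyl on the ring, in the place now held by fluoro, would be a further test of this position, and only a value that is a measured number would make such a step readable.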